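A few compounds are considered here, and "the series" means these few. Any claim that something is new, unique, unknown or untested is made for them only; others in the source may bear on it.

Compound 2 `O=C1N/C(=N/c2csc(-c3ccc(Cl)cc3)c2)S/C1=C\c1ccc2ccccc2c1` carries naphthalen-2-yl. In a functional assay on SW-620 cells (Homo sapiens) for cytotoxicity, read by MTT assay, with a stated time of 72 h (on this read-out lower numbers stand for stronger inhibition and higher numbers for weaker inhibition), compound 2 reaches only the assay limit of > 50000 nM, which is a limit and not a number. Compound 1 `Cc1ccc(/C=C2\S/C(=N\c3csc(-c4ccc(Cl)cc4)c3)NC2=O)cc1`, with 4-methylphenyl in that place, gives 1500 nM in this assay. The step of an at least 33-fold higher number from compound 1 to compound 2 (1.52 log units; beyond the scatter) rests on that limit (the limit of > 50000 nM in this assay, at which 1 of the 2 values shown sits). Compound 3 `O=C1N/C(=N/c2csc(-c3ccc(Cl)cc3)c2)S/C1=C\c1ccc(F)cc1` differs from compound 2 by 4-fluorophenyl in place of naphthalen-2-yl on a double-bonded chain carbon bound to a double-bonded ring carbon. That single measured step at this place went from one ring to two and was large. Moving back to one ring, compound 3 is expected to recover most of it, an at least 20-fold lower number from compound 2 to compound 3 (1.30 log units; beyond the scatter). Compound 3 is therefore estimated at 2500 nM, within 800 nM to 15000 nM.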

Compound 3, half-maximal inhibitory concentration: 8700 nM
Compound 3: the middle estimate sits 3.5-fold (0.54 log units) below what was measured; the measured number falls inside the stated range.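

Going from two rings to one at this place gives an at least 5.7-fold lower number from compound 2 to compound 3 (0.75 log units; beyond the scatter) and shows that the lower number does not depend on 4-methylphenyl alone. The value of compound 2 is a limit and not a number: the limit of > 50000 nM in this assay, at which 1 of the 3 values shown sits. With one ring kept, the group on it still matters, since fluoro in place of methyl on an aromatic carbon gives a 5.8-fold higher number from compound 1 to compound 3 (0.76 log units; beyond the scatter) and does not reach the number of compound 1. From the compounds shown here alone, it remains open whether a methoxy group or a chlorine on that ring would behave more like methyl or like fluoro. Going by these compounds, the effect of an amine or a carboxylic acid there is also open.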